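Urea series: tert-butyl to methyl step

The compounds below may be only part of what the source reports. "The series", "measured", "known", "first", "only" and "open" are said of these compounds alone.

Within the data shown here, compound 1 `CC(C)(C)NC(=O)N1CC1C#N` stands at the top of the three numbers so far: in a functional assay on WiDr cells (Homo sapiens) for inhibition (a lower number here means a stronger inhibitor, a higher number a weaker inhibitor), compound 1 gives 180000 nM. Compound 2 `N#CC1CN1C(=O)NC1CCCCC1` gives 2400 nM in this assay, and compound 3 `N#CC1CN1C(=O)Nc1cccnc1` gives 6000 nM; both sit beyond the scatter from compound 1, which is therefore the weakest of the three. Compound 4 `CNC(=O)N1CC1C#N` differs from compound 1 by methyl in place of tert-butyl on an amide-type nitrogen. Among the measured compounds shown here, no measured pair shows this step, and none of the measured compounds carries a methyl at that place, so the set gives no direct guide. The step from compound 1 to compound 4 is expected to be small, if anything towards a higher number, a 1.4-fold higher number from compound 1 to compound 4 (0.14 log units; within the scatter). Compound 4 is estimated at 250000 nM, with a range of 60000 nM to 1000000 nM.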

Compound 4, half-maximal inhibitory concentration: 21000 nM
Estimate against measurement, compound 4: 12-fold (1.08 log units) above; the whole stated range lies above it.
By their numbers in this assay, from the lowest: compound 2; then compound 3; then compound 4; then compound 1.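

In this assay the change of tert-butyl to methyl on the amide-type nitrogen is a real step: the move an 8.6-fold lower number from compound 1 to compound 4 (0.93 log units; beyond the scatter) shows that this position responds to its substituent, and that of these two groups methyl gives the stronger inhibitor. No measurement shown explains the step. As far as these compounds go, whether ethyl or isopropyl would fall between methyl and tert-butyl remains open. So does the result of a bare amide hydrogen at this place, or of a longer chain carrying an amine.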